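Acetyl on the sulfonamide nitrogen of compound 3

The source may report more compounds than this note shows. Statements on the series, on what has been measured and on what is new or still open speak of the compounds shown alone.

Compound 3 `NS(=O)(=O)c1ccc(-n2nc(-c3ccccc3)cc2-c2cc(O)ccc2O)cc1` gives 100000 nM in a functional assay on cells (Leukemia cell, Homo sapiens) for cytotoxicity, read by sulforhodamine B assay, with a stated time of 48 h; on this read-out lower numbers stand for stronger inhibition of growth and higher numbers for weaker inhibition of growth; it stands level with compound 2 `Oc1ccc(O)c(-c2cc(-c3ccccc3)nn2-c2ccccc2)c1`, which gives 100000 nM, and the two share the highest numbers of the three measured compounds. Compound 1 `COc1ccc(OC)c(-c2cc(-c3ccccc3)nn2-c2ccc(S(=O)(=O)NC(C)=O)cc2)c1` gives 53400 nM, the furthest of the set, yet still within the scatter of compound 3. The step of no change at the digits printed from compound 2 to compound 3 (within the scatter) shows that adding the sulfamoyl group left the read-out unchanged. Compound 4 `CC(=O)NS(=O)(=O)c1ccc(-n2nc(-c3ccccc3)cc2-c2cc(O)ccc2O)cc1` differs from compound 3 by acetyl in place of hydrogen on a sulfonamide nitrogen. Among the compounds with values here, no measured pair isolates this change; compound 1 carries the acetylsulfamoyl group but differs elsewhere too, so only its value can be set beside compound 3. Within the data shown here, with the only neighbouring step flat, no movement beyond the scatter is expected, so compound 4 is estimated at 90000 nM (range 45000 nM to 100000 nM), a step of a 1.1-fold lower number from compound 3 to compound 4 (0.05 log units; within the scatter).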

Compound 4, concentration for total growth inhibition: 100000 nM
The estimate for compound 4 lay 1.1-fold (0.05 log units) below the measured number; measured number inside the range.
By their numbers in this assay, from the lowest: compounds 1, 2, 3 and 4 (each within the scatter of the next).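

In this assay the sulfonamide nitrogen now has a direct pair: acetyl in place of hydrogen gives no change at the digits printed from compound 3 to compound 4 (within the scatter) and the position reads flat for this change. Acetylsulfamoyl in place of hydrogen on an aromatic carbon gives no change at the digits printed from compound 2 to compound 4 (within the scatter) and 2,5-dihydroxyphenyl in place of 2,5-dimethoxyphenyl gives a 1.9-fold higher number from compound 1 to compound 4 (0.27 log units; within the scatter) so neither the group nor the aryl exchange separates these compounds. No measured evidence bears on these steps. Open, as far as these compounds go, is whether a longer acyl chain such as butanoyl, or an amine or carboxylic acid carried on the sulfonamide nitrogen, would move the read-out beyond the scatter.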